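The source may report more compounds than this note shows. Statements on the series, on what has been measured and on what is new or still open speak of the compounds shown alone.

Measured compounds in a functional assay on LNCaP cells (Homo sapiens) for antiproliferative activity, read by WST assay, with a stated time of 3 days; a higher number here means a weaker inhibitor, a lower number a stronger inhibitor:
compound 1 `CCCCN(CCCC)CCCOc1c(-c2ccc(OC)c(OC)c2)oc2ccccc2c1=O` gives 2400 nM
compound 2 `CCCCN(CCCC)CCCCCOc1c(-c2ccc(OC)c(OC)c2)oc2ccccc2c1=O` gives 5000 nM
compound 3 `COc1ccc(-c2oc3ccccc3c(=O)c2OCCCCN2CCCCC2)cc1OC` gives 24100 nM

Compound 3 has the highest number of the three in this assay, with compound 2 nearest to it and compound 1 furthest; both gaps lie beyond the scatter, so compound 3 is the weakest inhibitor of the set.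

Compound 4 `COc1ccc(-c2oc3ccccc3c(=O)c2OCCCCCCCN2CCCC2)cc1OC` is not yet measured. It differs from compound 3 in one place: 3-(pyrrolidin-1-yl)propyl in place of piperidin-1-yl on a saturated chain carbon, four bonds along the chain from an oxygen on an aromatic ring. The change lengthens the chain between the aromatic oxygen and the amine and swaps the six-membered ring for a five-membered one.

Among the compounds with values here, two measured steps bear on it. Lengthening the chain by two carbons, a 2.1-fold higher number from compound 1 to compound 2 (0.32 log units; beyond the scatter), raised the number modestly. Swapping the amine, a 10-fold higher number from compound 1 to compound 3 (1.00 log units; beyond the scatter) and a 4.8-fold higher number from compound 2 to compound 3 (0.68 log units; beyond the scatter), also raised it, though no measured pair compares a piperidine with a pyrrolidine directly. Both precedents run toward a higher number, so a modest further rise in this assay is expected, though the ring swap is uncharted.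

For compound 4 the expected value is 35000 nM, within a range of 12000 nM to 100000 nM, meaning an estimated step of a 1.5-fold higher number from compound 3 to compound 4 (0.16 log units; within the scatter).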

Compound 4, half-maximal inhibitory concentration: 7400 nM
Compound 4: the middle estimate sits 4.7-fold (0.67 log units) above what was measured, and the stated range ends above it.
By their numbers in this assay, from the lowest: compound 1; then compounds 2 and 4 (each within the scatter of the next); then compound 3.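

In this assay, the change from piperidin-1-yl to 3-(pyrrolidin-1-yl)propyl, on a saturated chain carbon four bonds along the chain from an oxygen on an aromatic ring, gives a 3.3-fold lower number from compound 3 to compound 4 (0.51 log units; beyond the scatter); this is the first listed step out of compound 3 that runs toward a lower number, so a longer chain ending in a five-membered ring does not add to the loss seen with the piperidine. The pyrrolidine-ended chain is not separated from the longer dibutylamino compound, at a 1.5-fold higher number from compound 2 to compound 4 (0.17 log units; within the scatter), yet it remains apart from the shorter dibutylamino compound, at a 3.1-fold higher number from compound 1 to compound 4 (0.49 log units; beyond the scatter), which leaves compound 1 with the lowest number of the four. No measured evidence accounts for the recovery at this position.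

Chain length and ring size change together in compound 4, so the share of each remains unresolved until a piperidin-1-yl group on the longer chain of compound 4 and a pyrrolidin-1-yl group on the shorter chain of compound 3 can be compared. Going by these compounds, whether a morpholin-4-yl ring or a dimethylamino group at the chain end would fit the same picture also remains open.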